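The compounds below may be only part of what the source reports. "The series", "measured", "known", "first", "only" and "open" are said of these compounds alone.

Compound 1 `CCc1cccc2c(OC)c(-c3occ(C)c3COC)ccc12` was tested in a functional assay on KBVIN cells (Homo sapiens) for cytotoxicity, read by MTT assay, with a stated time of 72 h (on this read-out lower numbers stand for an effect already at smaller amounts and higher numbers for an effect only at larger amounts of compound), and gives 8.8 ug/mL. Compound 2 `CCOCc1c(C)coc1-c1ccc2c(CC)cccc2c1OC` carries a methyl in place of hydrogen on a saturated chain carbon bound to an oxygen on a saturated carbon, and in this assay compound 2 returns only a limit, > 10 ug/mL, so its place on the scale is known only as a range and not as a number. The step of an at least 1.1-fold higher number from compound 1 to compound 2 (0.05 log units; that floor lies within the scatter) thus has a floor that lies within the scatter, and this reading rests on (the limit of > 10 ug/mL in this assay, at which 1 of the 2 values shown sits). Compound 3 `CCc1cccc2c(OC)c(-c3occ(C)c3CBr)ccc12` differs from compound 2 by bromo in place of ethoxy on a saturated chain carbon bound to an aromatic carbon. For the measured compounds named here, no measured step touches this change: the single recorded step concerns a methyl gained on an alkoxy group and not the exchange of an ethoxy group for a bromo group, so neither its size nor its direction can be carried over. With compound 2 fixed only as a limit, the step in this assay is open in size and direction. Compound 3 is estimated at 5 ug/mL, with a range from 1 ug/mL to 20 ug/mL. For compound 3 the expected step is an at least 2.0-fold lower number from compound 2 to compound 3 (0.30 log units; that floor lies within the scatter), held loosely.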

Compound 3, concentration for half-maximal effect: > 10 ug/mL
Compound 3 gave a limit, no number (the forecaster's own chance of this, stated with the estimate: 30%); middle value at least 2.0-fold (0.30 log units) away from the limit.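

In this assay the change from ethoxymethyl to bromomethyl, on a saturated chain carbon bound to an aromatic carbon, again yields no number, and compound 3 gives > 10 ug/mL, which is a limit. For the compounds shown here, the one readable step for this position is bromo in place of methoxy, an at least 1.1-fold higher number from compound 1 to compound 3 (0.05 log units; that floor lies within the scatter), so a bromo group at this carbon shows no shift beyond the scatter, though a larger one is not excluded. The step for bromo in place of ethoxy cannot be read, because the two values rest on the same limit: the limit of > 10 ug/mL in this assay, at which 2 of the 3 values shown sit.

The compounds shown leave open how far compound 2 and compound 3 actually lie from that limit, and so whether either truly differs from compound 1 by more than the scatter. On these data alone, it also remains open whether an amine, a hydroxyl or a longer alkoxy chain on this carbon would give a value that can be read as a number.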